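Sulfone series: fluoro to chloro on the pendant phenyl

A few compounds are considered here, and "the series" means these few. Any claim that something is new, unique, unknown or untested is made for them only; others in the source may bear on it.

Compound 2 `O=S(=O)(c1cc(Cl)cc(Cl)c1)c1cnc2cc(F)ccc2c1-c1cccc(F)c1` stands lowest of the two values known in an ADME assay on microsomes from liver (Homo sapiens) for metabolic stability, tested at 2.5 uM (on this read-out higher numbers stand for fast clearance and lower numbers for slow clearance), at 0.41 mL/min. Compound 1 `COc1cccc(S(=O)(=O)c2cnc3cc(F)ccc3c2-c2cccc(Cl)c2)c1` gives 2.97 mL/min, a higher number with a gap beyond the usual scatter; the two differ in more than one place, so no single step can be read from them. Compound 3 `O=S(=O)(c1cc(Cl)cc(Cl)c1)c1cnc2cc(F)ccc2c1-c1cccc(Cl)c1` carries chloro in place of fluoro on an aromatic carbon. Among the compounds with values here, no measured pair isolates this change. For it the expected step is small, if anything toward faster clearance, and likely within the scatter: a 1.3-fold higher number from compound 2 to compound 3 (0.13 log units; within the scatter). Compound 3 is expected at 0.55 mL/min, within 0.25 mL/min to 1.3 mL/min.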

Compound 3, intrinsic clearance in a liver preparation (reported as CLH), per the amount of preparation that the assay uses: 0.93 mL/min
For compound 3 the middle estimate is 1.7-fold (0.23 log units) below the measured one; the measured number falls inside the stated range.
By their numbers in this assay, from the lowest: compound 2; then compound 3; then compound 1.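

In this assay, the change from 3-fluorophenyl to 3-chlorophenyl now has a measured size (a 2.3-fold higher number from compound 2 to compound 3 (0.36 log units; beyond the scatter)), so the number at this position responds to the choice of halogen, with fluoro giving the lower value. With the chloro in place, the sulfonyl side also matters: 3,5-dichlorophenyl in place of 3-methoxyphenyl gives a step in the opposite direction (a 3.2-fold lower number from compound 1 to compound 3 (0.50 log units; beyond the scatter)). No measurement at hand offers a reason for either step.

Still open, on these data alone, is where a nitrile or a methyl would fall at the halogen position. Also open, as far as these compounds go, is whether the sulfonyl-side step holds with fluoro in place of chloro.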